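This account rests on a few compounds, and the source may have more. Where it says the series, first, only, none or still open, it means among the compounds named here.

Measured so far in a functional assay on HCT-116 cells (Homo sapiens) for cytotoxicity, read by MTT assay, with a stated time of 3 days; on this read-out higher numbers stand for weaker inhibition and lower numbers for stronger inhibition:
- compound 1 `CN(C)Cc1ccc(/C=N/Nc2ncnc3sc(C(C)(C)C)cc23)cc1` gives 0.128 ug/mL
- compound 2 `CC(C)(C)c1cc2c(N/N=C/c3ccc(C(=O)O)cc3)ncnc2s1` gives 9.99 ug/mL
- compound 3 `CC(C)N1Cc2ccc(/C=N/Nc3ncnc4sc(C(C)(C)C)cc34)cc2C1` gives 0.206 ug/mL

Compound 2 has the highest number of the three, well clear of both others. The next step leads to compound 4 `CNCc1ccc(/C=N/Nc2ncnc3sc(C(C)(C)C)cc23)cc1` and is (methylamino)methyl in place of carboxy on an aromatic carbon. The nearest measured evidence is a 78-fold higher number from compound 1 to compound 2 (1.89 log units; beyond the scatter), a large step with carboxy in place of (dimethylamino)methyl on an aromatic carbon. Read in reverse, it points to a large move towards a lower number in this assay, though (methylamino)methyl itself is unmeasured. The expected step is a 62-fold lower number from compound 2 to compound 4 (1.80 log units; beyond the scatter) as estimated here. Compound 4 is estimated at 0.16 ug/mL (expected range 0.06 ug/mL to 0.6 ug/mL).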

Compound 4, half-maximal inhibitory concentration: 0.056 ug/mL
Estimate against measurement, compound 4: 2.9-fold (0.46 log units) above, and the stated range ends above it.
By their numbers in this assay, from the lowest: compound 4; then compounds 1 and 3 (each within the scatter of the next); then compound 2.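

In this assay, (methylamino)methyl in place of carboxy on this aromatic carbon gives a 180-fold lower number from compound 2 to compound 4 (2.25 log units; beyond the scatter), so the large gap seen with the earlier tertiary amine also holds for a secondary amine. Substitution on the amine nitrogen also matters: hydrogen in place of methyl gives a 2.3-fold lower number from compound 1 to compound 4 (0.36 log units; beyond the scatter), a modest step. No available evidence accounts for either step. Still open, on these data alone, is whether an unsubstituted aminomethyl group or a longer chain on the amine nitrogen would shift the number further, and where an amide at this position would fall.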